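This account rests on a few compounds, and the source may have more. Where it says the series, first, only, none or still open, it means among the compounds named here.

Working notes on the series, the shared core of compound 1 `Fc1cccc(F)c1Cn1ccc2nc(-c3c(F)cccc3F)nc-2c1` carried through.

Cytotoxicity is read in an ADME assay on MDBK cells (Bos taurus) for cytotoxicity; on this read-out lower numbers stand for higher toxicity in this test and higher numbers for lower toxicity in this test. In this assay compound 1 gives > 100000 nM, which is a limit of the assay and not a number. Compound 2 `Fc1cccc(F)c1-c1nc2ccn(Cc3ccccc3)cc-2n1` in this assay gives > 100000 nM, again a limit. Compound 3 `Cc1ccc(Cn2ccc3nc(-c4ccccc4)nc-3c2)cc1` in this assay gives > 100000 nM, also a limit. Going by the values given here, the only single-point step among the measured compounds, a step that the two limits leave unreadable from compound 1 to compound 2, is therefore left unreadable by the two limits at its ends. Compound 3 thus stands at the common ceiling of the series: the evidence is the limit of > 100000 nM in this assay, at which 3 of the 3 values shown sit, and nothing shown separates the three compounds from one another.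

Compound 4 `Brc1ccccc1Cn1ccc2nc(-c3ccccc3)nc-2c1` differs from compound 3 as follows (2-bromophenyl in place of 4-methylphenyl on a saturated chain carbon bound to an aromatic nitrogen). Among the compounds with values here, no measured step bears directly on this change, and the one step that touches the same place is itself unreadable. The expectation for compound 4 in this assay therefore rests only on the shared ceiling, and compound 4 is estimated at 150000 nM, within 60000 nM to 400000 nM, most likely again reported as a limit. The step this implies, a step that the limit leaves unreadable from compound 3 to compound 4, is expected to lie within the scatter.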

Compound 4, half-maximal cytotoxic concentration: > 100000 nM
Compound 4 was reported as a limit; the forecaster's own chance of this, stated with the estimate: 80%; the middle value does not contradict the limit.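

In this assay, going by these compounds alone, compound 3 and compound 4 both stand at a limit of the assay, so the step between them cannot be read and no new step follows. The series remains at its common ceiling: the limit of > 100000 nM in this assay, at which 4 of the 4 values shown sit.

The compounds shown leave open whether any change on the shared core would give a readable value, and how large the effect of such a change would be.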